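A few compounds are considered here, and "the series" means these few. Any claim that something is new, unique, unknown or untested is made for them only; others in the source may bear on it.

Compound 1 `CCOC(=O)C12C(=O)OCC=C1COC2c1ccccc1` gives 12800 nM in a functional assay on HeLa cells (Homo sapiens) for cytotoxicity, read by MTT assay; a lower number here means a stronger inhibitor, a higher number a weaker inhibitor. Compound 2 `CCOC(=O)C12C(=O)OCC=C1COC2c1ccc(OC)cc1` gives 18300 nM in this assay. Compound 3 `CCOC(=O)C12C(=O)OCC=C1COC2c1cc(OC)c(OC)c(OC)c1` gives 5400 nM in this assay.

Among these three numbers compound 1 holds the second highest place. Its nearest neighbour is compound 2, reached by a 1.4-fold higher number from compound 1 to compound 2 (0.16 log units; within the scatter), a step that stays within the scatter. Within the data shown here, the furthest is compound 3, whose number is lower than that of compound 1 by a gap that lies beyond the scatter; no single-place step links these two compounds.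

Compound 4 `CCOC(=O)C12C(=O)OCC=C1COC2c1ccco1` differs from compound 1 by furan-2-yl in place of phenyl on a saturated ring carbon. Among the measured compounds shown here, none of the measured steps exchanges the aromatic ring itself; the only step recorded, a 1.4-fold higher number from compound 1 to compound 2 (0.16 log units; within the scatter), adds a methoxy to that ring and stays within the scatter. Nothing in the data therefore points to a change beyond the scatter in this assay, and the expected step is a 1.1-fold lower number from compound 1 to compound 4 (0.03 log units; within the scatter). Compound 4 is accordingly estimated at 12000 nM, with a range from 5000 nM to 30000 nM.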

Compound 4, half-maximal inhibitory concentration: 28300 nM
For compound 4 the middle estimate is 2.4-fold (0.37 log units) below the measured one; the measured number falls inside the stated range.
By their numbers in this assay, from the lowest: compound 3; then compounds 1, 2 and 4 (each within the scatter of the next, the first and the last beyond it).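

Exchanging the aromatic ring itself on this saturated ring carbon, with furan-2-yl in place of phenyl, changes the result in this assay: the step is a 2.2-fold higher number from compound 1 to compound 4 (0.34 log units; beyond the scatter), a modest move towards a weaker inhibitor. The earlier single-place step, a 1.4-fold higher number from compound 1 to compound 2 (0.16 log units; within the scatter), added methoxy to the phenyl ring and stayed within the scatter, so only the new step shows that this position can respond to a change beyond the scatter. The data shown offer no measured explanation for this shift.

The compounds shown leave open whether a thiophen-2-yl or pyridin-2-yl ring at this carbon would give a number closer to that of compound 1 or compound 4. Also open, from the compounds shown here alone, is what a carboxylic acid or an amide in place of the ethoxycarbonyl group would do in this assay.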